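The source may hold more compounds than are shown below. What is called first, only, known or untested is meant among the compounds shown, and "the series" means these compounds.

Measured so far:
Compound 1, `CN(C(=O)NC(=O)c1ccc(Cl)cc1Cl)c1nc(C(F)(F)F)c(C(=O)N/N=C/c2cccc(C(F)(F)F)c2)s1`, gives 10.6 ug/mL in a functional assay on A549 cells (Homo sapiens) for inhibition, read by MTT assay, with a stated time of 72 h; on this read-out lower numbers stand for stronger inhibition and higher numbers for weaker inhibition.
Compound 2, `Cc1nc(N(C)C(=O)NC(=O)c2c(F)cccc2F)sc1C(=O)N/N=C/c1cccc(C(F)(F)F)c1`, gives 30.3 ug/mL in this assay.
Compound 3, `CN(C(=O)NC(=O)c1ccc(Cl)cc1Cl)c1nc(C(F)(F)F)c(C(=O)N/N=C/c2ccccc2C(F)(F)F)s1`, gives 15.3 ug/mL in this assay.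

Compound 1 and compound 3 share one core; the difference between that core and the core of compound 2 is not broken down here. Compound 2 has the highest of the three numbers in this assay; its gap to compound 3 is within the scatter, its gap to compound 1 beyond it.

The change from compound 1 to compound 3 is 2-(trifluoromethyl)phenyl in place of 3-(trifluoromethyl)phenyl on a carbon with a double bond to nitrogen, and it made a step of a 1.4-fold higher number from compound 1 to compound 3 (0.16 log units; within the scatter). The same change, (2-(trifluoromethyl)phenyl in place of 3-(trifluoromethyl)phenyl on a carbon with a double bond to nitrogen), turns compound 2 into compound 4, `Cc1nc(N(C)C(=O)NC(=O)c2c(F)cccc2F)sc1C(=O)N/N=C/c1ccccc1C(F)(F)F`, which still awaits measurement in this assay.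

Since the change has been seen only once, the step expected from compound 2 to compound 4 is a 1.3-fold higher number from compound 2 to compound 4 (0.12 log units; within the scatter), close in size to the earlier one, resting on the value of compound 2, 30.3 ug/mL, and on a 1.4-fold higher number from compound 1 to compound 3 (0.16 log units; within the scatter).

Compound 4 is therefore estimated at 40 ug/mL, with a range from 20 ug/mL to 85 ug/mL.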

Compound 4, half-maximal inhibitory concentration: 5.43 ug/mL
For compound 4 the middle estimate is 7.4-fold (0.87 log units) above the measured one, outside the stated range (below it).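

In this assay the swap of 2-(trifluoromethyl)phenyl in place of 3-(trifluoromethyl)phenyl makes a step of a 5.6-fold lower number from compound 2 to compound 4 (0.75 log units; beyond the scatter) towards stronger inhibition on this core. Carried from one core to the other, the change does not keep its size: the same change on two cores in this assay, a 1.4-fold higher number (0.16 log units; within the scatter) from compound 1 to compound 3 and a 5.6-fold lower number (0.75 log units; beyond the scatter) from compound 2 to compound 4, 8.1-fold (0.91 log units) apart, beyond the scatter of two such steps

A step read on one core therefore gave no reliable guide to the step on the other here, yet with one pair per core this does not show which difference between the cores goes with the gap, nor how the change would behave on a further core. Open is whether the size of the step follows the methyl or trifluoromethyl group of the cores or the chlorine- or fluorine-bearing benzoyl part, as no compound shown separates them. Also open, as far as these compounds go, is how an amine or a carboxylic acid on the phenyl ring would compare with trifluoromethyl on either core.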